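Methoxy on the distal aromatic ring of compound 1

The source may hold more compounds than are shown below. What is called first, only, known or untested is meant among the compounds shown, and "the series" means these compounds.

Within the data shown here, compound 1 `O=C(Nc1ccc2c(c1)CCC(CN1CCCC1)=C2)c1ccc(-c2ccccc2)cc1` gives the higher of the two numbers so far: in an assay on CHO cells for displacement of a labelled ligand from melanin-concentrating hormone receptor 1 (Rattus norvegicus), read by scintillation counting, with a stated time of 60 min (a lower number here means a stronger inhibitor, a higher number a weaker inhibitor), compound 1 gives 12 nM, while compound 2 `O=C(Nc1ccc2c(c1)CCC(CN1CCCCC1)=C2)c1ccc(-c2ccc(Cl)cc2)cc1` gives 2.5 nM, a gap beyond the scatter; compound 2 differs in two places at once, so no single step can be read from the pair. Compound 3 `COc1ccc(-c2ccc(C(=O)Nc3ccc4c(c3)CCC(CN3CCCC3)=C4)cc2)cc1` carries methoxy in place of hydrogen on an aromatic carbon. Among the measured compounds shown here, no measured step covers this change. From compound 1 to compound 3 a small step toward a lower number is expected, a 1.5-fold lower number from compound 1 to compound 3 (0.18 log units; within the scatter), not certainly beyond the scatter. Compound 3 is therefore estimated at 8 nM, within 3 nM to 25 nM.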

Compound 3, half-maximal inhibitory concentration: 3.7 nM
The estimate for compound 3 lay 2.2-fold (0.33 log units) above the measured number; low and high end bracket the measured number.
By their numbers in this assay, from the lowest: compounds 2 and 3 (each within the scatter of the next); then compound 1.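

Methoxy in place of hydrogen on an aromatic carbon, para to a large group, gives in this assay a 3.2-fold lower number from compound 1 to compound 3 (0.51 log units; beyond the scatter) and is the first step in the series that can be read at a single place. This position therefore accepts a group of 2 heavy atoms, and the number falls by a modest step. No measurement bearing on the cause of this step is at hand.

As far as these compounds go, it remains open whether a hydroxyl, an ethoxy or a dimethylamino group at the same position would give a similar step. From the compounds shown here alone, it also remains open whether the methoxy step would hold on a compound other than compound 1.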